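Lengthening the Amide Chain: From Compound 2 to Compound 3

The compounds below may be only part of what the source reports. "The series", "measured", "known", "first", "only" and "open" are said of these compounds alone.

Measured compounds:
compound 1 `CCCCCC(=O)NCC(C)(C)CC1=C(O)C(=O)c2ccccc2C1=O`: 40200 nM
compound 2 `CCCCCCC(=O)NCC(C)(C)CC1=C(O)C(=O)c2ccccc2C1=O`: 28200 nM

Of the two numbers in a functional assay on KB cells (Homo sapiens) for cytotoxicity, read by resazurin assay, with a stated time of 3 days (a lower number here means a stronger inhibitor, a higher number a weaker inhibitor), compound 2 has the lowest, though its only neighbor, compound 1, sits within the scatter: a 1.4-fold lower number from compound 1 to compound 2 (0.15 log units; within the scatter). Compound 3 `CCCCCCCCC(=O)NCC(C)(C)CC1=C(O)C(=O)c2ccccc2C1=O` differs from compound 2 by ethyl in place of hydrogen on a saturated chain carbon, six bonds along the chain from a carbonyl carbon, the same kind of chain lengthening that turned compound 1 into compound 2. That step is the only one that bears on the question, and it was small. A further small drop in number, not clearly beyond the scatter, is therefore expected for compound 3: a 1.4-fold lower number from compound 2 to compound 3 (0.15 log units; within the scatter). The value of compound 3 in this assay is estimated at 20000 nM, with a range from 9000 nM to 45000 nM.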

Compound 3, half-maximal inhibitory concentration: 19700 nM
Estimate against measurement, compound 3: 1.0-fold (0.01 log units) above; the range from low to high includes it.
By their numbers in this assay, from the lowest: compounds 3, 2 and 1 (each within the scatter of the next, the first and the last beyond it).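

In this assay the further lengthening gives a 1.4-fold lower number from compound 2 to compound 3 (0.16 log units; within the scatter) and so, like the earlier step, stays small on its own. Only the whole span gives a 2.0-fold lower number from compound 1 to compound 3 (0.31 log units; beyond the scatter) and thereby passes the scatter, though modestly, which shows that these small steps at this chain position can add up to a measurable difference. Nothing available explains this drift. Going by these compounds, whether a longer chain would continue it remains open, as does whether an amine or a carboxylic acid in place of the added ethyl would depart from it.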